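This account rests on a few compounds, and the source may have more. Where it says the series, first, only, none or still open, it means among the compounds named here.

Measured compounds:
Compound 1, `CCCCNC(=S)NC1=C(C#N)C(c2ccc(Cl)cc2Cl)C2=C(CCCC2=O)N1c1ccc(S(N)(=O)=O)cc1`: 30%
Compound 2, `N#CC1=C(NC(=S)Nc2ccccc2)N(c2ccc(S(N)(=O)=O)cc2)C2=C(C(=O)CCC2)C1c1ccc(Cl)cc1Cl`: 40%

In a functional assay on Ehrlich cells (Mus musculus) for cytotoxicity, read by trypan blue exclusion, with a stated time of 2 h, tested at 10 ug/mL (a higher number here means a stronger effect of the compound at the concentration tested, a lower number a weaker effect), compound 2 gives 40%. On the numbers shown, compound 2 stands together with compound 1, which gives 30%; the one measured step, a number 10 percentage points higher from compound 1 to compound 2 (within the scatter), does not separate the two compounds.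

The unmeasured compound 3, `N#CC1=C(NC(=S)Nc2ccc(Cl)cc2)N(c2ccc(S(N)(=O)=O)cc2)C2=C(C(=O)CCC2)C1c1ccc(Cl)cc1Cl`, differs from compound 2 in one place: chloro in place of hydrogen on an aromatic carbon.

Going by the values given here, no measured step bears directly on a chloro in place of hydrogen on an aromatic carbon. Among the compounds with values here, the only step available, phenyl in place of butyl on an amide-type nitrogen, a number 10 percentage points higher from compound 1 to compound 2 (within the scatter), stayed within the scatter, so the series gives no sign that a change at this part of the molecule moves the read-out. The expected step is therefore none beyond the scatter: no change at the digits printed from compound 2 to compound 3 (within the scatter).

Compound 3 is estimated to give 40% in this assay, with a range from 25% to 55%.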

Compound 3, a percentage reported as activity, at one concentration (the size of the read-out at that concentration, not a potency): 30%
Compound 3: middle estimate off by 10 percentage points, on the high side; the measured number falls inside the stated range.
By their numbers in this assay, from the lowest: compounds 1, 3 and 2 (each within the scatter of the next).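

In this assay, chloro in place of hydrogen on an aromatic carbon gives a number 10 percentage points lower from compound 2 to compound 3 (within the scatter), so this first substitution on the phenyl ring, para to a large group, does not separate compound 3 from its parent. Set against the butyl compound, 4-chlorophenyl in place of butyl on an amide-type nitrogen gives no change at the digits printed from compound 1 to compound 3 (within the scatter), so the chlorinated aryl group is not separated from the open chain either. Nothing measured on these compounds accounts for this result.

On these data alone, whether a methoxy group or an amine at the same place, or a chain longer than butyl on the amide-type nitrogen, would move the read-out beyond the scatter stays open. All three compounds also keep the nitrile and the sulfonamide, so the role of those groups is open too.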